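Swapping the 4-methylpiperazin-1-yl group of compound 3

The source may hold more compounds than are shown below. What is called first, only, known or untested is meant among the compounds shown, and "the series" means these compounds.

Measured so far in a physicochemical assay for permeability, using PAMPA; on this read-out higher numbers stand for higher permeability and lower numbers for lower permeability:
- Compound 1 `N[C@H]1CC[C@H](Nc2ccc3ncc(-c4cnc(Nc5ccccc5)nc4)n3n2)CC1` gives 2 nm/s
- Compound 2 `N[C@H]1CC[C@H](Nc2ccc3ncc(-c4cnc(NCc5ccccn5)nc4)n3n2)CC1` is recorded as "not determined" (no result reported)
- Compound 3 `CN1CCN(c2ccc3ncc(-c4cnc(Nc5ncccc5F)nc4)n3n2)CC1` gives 61 nm/s

For the measured compounds named here, only two numbers are available, and compound 3 holds the higher one at 61 nm/s on this scale. Compound 1 lies far lower with 2 nm/s here, a gap well beyond the usual scatter of repeat measurements. These two compounds differ in more than one place, so their gap cannot be pinned on any single group.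

The next compound is compound 4 `CN1CC[C@H](Oc2ccc3ncc(-c4cnc(Nc5ncccc5F)nc4)n3n2)C1`, which keeps the rest of compound 3 and changes one group, with (1-methylpyrrolidin-3-yl)oxy in place of 4-methylpiperazin-1-yl on an aromatic carbon.

Going by the values given here, no pair of measured compounds differs in only one place, so nothing here tests such a swap directly and any forecast in this assay stays loose. Compound 3 with 61 nm/s is the top of a very small set, and a new compound is more likely to land below such a value than beyond it. A modest fall is therefore expected, close to the edge of the scatter. The estimated change is a 2.2-fold lower number from compound 3 to compound 4 (0.34 log units; beyond the scatter) in this read-out. For compound 4 the estimated value is 28 nm/s with a likely range from 7 nm/s to 90 nm/s in this read-out.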

Compound 4, apparent permeability: 28 nm/s
Beside the measured number, compound 4's estimate shows no gap at the digits printed; measured number inside the range.
By their numbers in this assay, from the lowest: compound 1; then compound 4; then compound 3.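

For the compounds shown here, replacing 4-methylpiperazin-1-yl with (1-methylpyrrolidin-3-yl)oxy gives a 2.2-fold lower number from compound 3 to compound 4 (0.34 log units; beyond the scatter) in this assay, the first comparison here in which only one group changes, so this step can be tied to this position on the aromatic carbon. The read-out moves even though the entering and leaving groups match in their counts of heavy atoms, hydrogen-bond donors and hydrogen-bond acceptors, so those counts alone do not fix the value at this position. No measurement here explains the step.

Going by these compounds, the swap alters several features at once, including the ring size, the atom joining the group to the aromatic carbon and the defined stereocentre, so the part each plays stays open, and a (1-methylpiperidin-4-yl)oxy group, with its oxygen link and six-membered ring, would help to separate the first two. Also open, on these data alone, are the mirror-image form of compound 4, an open-chain amine such as 2-(dimethylamino)ethoxy on the same carbon, and whether the same swap would have a similar effect on the core of compound 1.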